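A few compounds are considered here, and "the series" means these few. Any claim that something is new, unique, unknown or untested is made for them only; others in the source may bear on it.

Compound 2 `N#Cc1ccc(NC(=O)c2ccc3cccnc3c2O)cc1` gives 130 nM in a functional assay on NALM-6 cells (Homo sapiens) for cytotoxicity, read by luminescence and CellTiter-Glo, with a stated time of 3 days (on this read-out lower numbers stand for stronger inhibition and higher numbers for weaker inhibition), the lowest of the three numbers recorded here. Its nearest neighbour is compound 3 `N#Cc1ccc(NC(=O)c2cc(Br)c3cccnc3c2O)cc1`, which in this assay gives 210 nM, with a 1.6-fold higher number from compound 2 to compound 3 (0.21 log units; within the scatter). Compound 1 `O=C(Nc1ccc(C(F)(F)F)cc1)c1ccc2cccnc2c1O` in this assay gives 380 nM, and the change from compound 1 to compound 2 gave a 2.9-fold lower number from compound 1 to compound 2 (0.47 log units; beyond the scatter).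

Compound 4 `N#Cc1ccc(NC(=O)c2ccc3cccnc3c2O)c(C#N)c1` has not yet been measured. It differs from compound 2 by cyano in place of hydrogen on an aromatic carbon, placed ortho to a large group on the same six-membered aromatic ring of carbon only. Going by the values given here, two measured steps bear on it loosely: a cyano group entering the ring gave the modest step of a 2.9-fold lower number from compound 1 to compound 2 (0.47 log units; beyond the scatter), while an added halogen on the core gave a 1.6-fold higher number from compound 2 to compound 3 (0.21 log units; within the scatter). Among the compounds with values here, no measured step adds a second cyano to an occupied ring, so the account expects a small step in this assay, likely within the scatter, for a 1.2-fold higher number from compound 2 to compound 4 (0.06 log units; within the scatter). Compound 4 is therefore expected to give about 150 nM, in the range 60 nM to 400 nM.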

Compound 4, half-maximal inhibitory concentration: 350 nM
For compound 4 the middle estimate is 2.3-fold (0.37 log units) below the measured one; low and high end bracket the measured number.
By their numbers in this assay, from the lowest: compounds 2, 3, 4 and 1 (each within the scatter of the next, the first and the last beyond it).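

In this assay, cyano in place of hydrogen, ortho to a large group and meta to a cyano group, gives a 2.7-fold higher number from compound 2 to compound 4 (0.43 log units; beyond the scatter), so this position on the six-membered aromatic ring of carbon only does respond to substitution. Going by these compounds alone, the earlier cyano step, in place of trifluoromethyl, gave a 2.9-fold lower number from compound 1 to compound 2 (0.47 log units; beyond the scatter), and the bromo step on the core gave a 1.6-fold higher number from compound 2 to compound 3 (0.21 log units; within the scatter), so the new step is the first replacement of a hydrogen on this ring and the first hydrogen replacement to move the number beyond the scatter. No measurement shown here explains this step.

The compounds shown leave open whether the step belongs to the cyano group or to the position itself, which a fluoro, methoxy or amine group at the same carbon could test. They also leave open how cyano would behave on the remaining carbons of this ring.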